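A few compounds are considered here, and "the series" means these few. Any claim that something is new, unique, unknown or untested is made for them only; others in the source may bear on it.

Measured compounds:
Compound 1 `Cc1nc(S(C)(=O)=O)ccc1Oc1ncnc(OC2CCN(C(=O)OC(C)(C)CF)CC2)c1F`: 19.9 nM
Compound 2 `Cc1nc(S(C)(=O)=O)ccc1Oc1ncnc(OC2CCN(C(=O)O[C@H](C)CF)CC2)c1F`: 196 nM
Compound 3 `Cc1nc(S(C)(=O)=O)ccc1Oc1ncnc(OC2CCN(C(=O)OC3COC3)CC2)c1F`: 326 nM

In a functional assay on isolated protein for inhibition of Glucose-dependent insulinotropic receptor (Homo sapiens), read by HTRF and cAMP accumulation (a higher number here means that more compound is needed for the effect, a lower number that less compound is needed), compound 3 gives 326 nM, the highest number of the three; it lies beyond the scatter only against compound 1 (a 16-fold higher number from compound 1 to compound 3 (1.21 log units; beyond the scatter)), while compound 2 sits within the scatter of it (a 1.7-fold higher number from compound 2 to compound 3 (0.22 log units; within the scatter)). Compound 4 `Cc1nc(S(C)(=O)=O)ccc1Oc1ncnc(OC2CCN(C(=O)C(F)(F)F)CC2)c1F` is not yet measured. The change is trifluoromethyl in place of (oxetan-3-yl)oxy on a carbonyl carbon.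

Among the compounds with values here, none of the measured steps bears directly on this change: each of them swaps one alkoxy substituent on the carbonyl for another, and all three compounds keep the oxygen on the carbonyl. The two steps beyond the scatter, a 9.8-fold higher number from compound 1 to compound 2 (0.99 log units; beyond the scatter) and a 16-fold higher number from compound 1 to compound 3 (1.21 log units; beyond the scatter), show that the group on that carbonyl can move the number strongly, and that the branched fluorinated group of compound 1 gives the lowest number. Losing the oxygen entirely in favour of trifluoromethyl is therefore uncharted; the expectation is a step of roughly a 1.8-fold higher number from compound 3 to compound 4 (0.26 log units; within the scatter), toward a higher number, with wide uncertainty. For compound 4 the estimate is 600 nM, range 150 nM to 2500 nM.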

Compound 4, half-maximal effective concentration: 151 nM
For compound 4 the middle estimate is 4.0-fold (0.60 log units) above the measured one; the measured number falls inside the stated range.
By their numbers in this assay, from the lowest: compound 1; then compounds 4, 2 and 3 (each within the scatter of the next, the first and the last beyond it).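

Oxygen on the carbonyl is not required for a number in this range in this assay: trifluoromethyl in place of (oxetan-3-yl)oxy gives a modest gain (a 2.2-fold lower number from compound 3 to compound 4 (0.33 log units; beyond the scatter)), while against the 1-(fluoromethyl)ethyl group of compound 2 the change stays small (a 1.3-fold lower number from compound 2 to compound 4 (0.11 log units; within the scatter)). The 1-(fluoromethyl)-1-methylethyl group of compound 1 remains clearly apart from trifluoromethyl (a 7.6-fold higher number from compound 1 to compound 4 (0.88 log units; beyond the scatter)), so the oxygen-free group does not match the best carbonyl substituent in this set. No measurement at hand explains these steps.

As far as these compounds go, whether the fluorines of trifluoromethyl matter, or only the absence of the oxygen, remains open, and a plain methyl or a dimethylamino group on the carbonyl carbon would separate the two. Also open, from the compounds shown here alone, is whether a tert-butyl group there would approach compound 1.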